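Sulfonyl aryl variation toward an unsubstituted phenyl

The source may report more compounds than this note shows. Statements on the series, on what has been measured and on what is new or still open speak of the compounds shown alone.

Measured so far in a functional assay on CHO cells for antagonist activity at 5-hydroxytryptamine receptor 6 (Homo sapiens), read by FLIPR; a higher number here means a weaker inhibitor, a lower number a stronger inhibitor:
compound 1 `CN1CCC(N(C)C(=O)C2CN(S(=O)(=O)C3=CC4CCOC4C=C3)c3ccccc32)CC1` gives 31.6 nM
compound 2 `CN1CCC(N(C)C(=O)C2CN(S(=O)(=O)c3ccc4c(c3)OCCO4)c3ccccc32)CC1` gives 50.1 nM
compound 3 `CN1CCC(N(C)C(=O)C2CN(S(=O)(=O)c3cccc4nsnc34)c3ccccc32)CC1` gives 126 nM

Compound 3 stands at the highest number of the three. Against its nearest neighbour the gap is a 2.5-fold higher number from compound 2 to compound 3 (0.40 log units; beyond the scatter); against compound 1 it is a 4.0-fold higher number from compound 1 to compound 3 (0.60 log units; beyond the scatter). The remaining pair is close, a 1.6-fold higher number from compound 1 to compound 2 (0.20 log units; within the scatter).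

Compound 4 is `CN1CCC(N(C)C(=O)C2CN(S(=O)(=O)c3ccccc3)c3ccccc32)CC1`. The change from compound 3 is a group of 6 heavy atoms (6 carbon; one six-membered aromatic ring of carbon only) in place of a group of 9 heavy atoms (6 carbon, 2 nitrogen, 1 sulfur; one five-membered aromatic ring with 3 hetero atoms, one six-membered aromatic ring of carbon only), on a sulfonyl sulfur.

All three measured steps concern the group on the sulfonyl sulfur, so all three bear on this change. The two steps beyond the scatter (a 4.0-fold higher number from compound 1 to compound 3 (0.60 log units; beyond the scatter) and a 2.5-fold higher number from compound 2 to compound 3 (0.40 log units; beyond the scatter)) are both modest and both lead into compound 3, the group that now leaves. Among the compounds with values here, no measured step replaces a fused bicyclic group with a single ring, and phenyl itself has not been measured, so the direction for compound 4 is open. Given that the whole spread of the series so far is modest, the step is expected to be small.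

Compound 4 is therefore estimated at 100 nM in this assay, with a range from 30 nM to 400 nM. This estimate means a step of a 1.3-fold lower number from compound 3 to compound 4 (0.10 log units; within the scatter), expected to fall within the scatter.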

Compound 4, inhibition constant: 316 nM
The estimate for compound 4 lay 3.2-fold (0.50 log units) below the measured number; low and high end bracket the measured number.
By their numbers in this assay, from the lowest: compounds 1 and 2 (each within the scatter of the next); then compound 3; then compound 4.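

In this assay the phenyl group on the sulfonyl sulfur gives the weakest inhibitor of the four, and all three groups carrying a second ring do better, with no compound shown going against this: a 2.5-fold higher number from compound 3 to compound 4 (0.40 log units; beyond the scatter), a 6.3-fold higher number from compound 2 to compound 4 (0.80 log units; beyond the scatter) and a 10-fold higher number from compound 1 to compound 4 (1.00 log units; beyond the scatter). The position therefore tolerates quite different second rings but responds more strongly to the loss of that ring, and the range of the series is wider than the three earlier compounds showed. Nothing at hand accounts for this difference, so it stands as an observation only.

The compounds shown do not separate the contribution of the second ring's carbon atoms from that of its oxygen, nitrogen or sulfur atoms, and naphthyl, with an all-carbon second ring, would be a direct test. From the compounds shown here alone, it also remains open whether a single ring can recover the lost inhibition, for example phenyl bearing a methoxy group or a chlorine atom, and the present compounds give no reading on where on the ring such a group should sit.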